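Sulfamoylphenyl replacement on the shared core, binding expectation

This account rests on a few compounds, and the source may have more. Where it says the series, first, only, none or still open, it means among the compounds named here.

Compound 1 `CCCS(=O)(=O)Nc1ccc(F)c(C(=O)c2n[nH]c3ncc(-c4ccc(F)cc4)cc23)c1F` and compound 2 `CCCS(=O)(=O)Nc1ccc(F)c(C(=O)c2n[nH]c3ncc(-c4ccc(C)c(C)c4)cc23)c1F` share one core and differ only in the aromatic group attached to it. In an assay for binding affinity to dual specificity mitogen-activated protein kinase kinase 4 (Homo sapiens), read by KINOMEscan, tested at 100 nM (a higher number here means a weaker effect of the compound at the concentration tested, a lower number a stronger effect), compound 1 gives 2.1%, while compound 2 gives 20%. For the measured compounds named here, the step of a number 17.9 percentage points higher from compound 1 to compound 2 (beyond the scatter) is the only measured step. Compound 2 thus stands as the higher of the two numbers, its nearest neighbour being compound 1, lower by more than the scatter.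

Compound 3 `CCCS(=O)(=O)Nc1ccc(F)c(C(=O)c2n[nH]c3ncc(-c4ccc(S(N)(=O)=O)cc4)cc23)c1F` differs from compound 2 by 4-sulfamoylphenyl in place of 3,4-dimethylphenyl on an aromatic carbon. Going by the values given here, no measured step covers a sulfamoylphenyl group; the one step known shows only that exchanging this aromatic group moves the read-out by a modest amount. The expectation for compound 3 is therefore a step of a number 10 percentage points lower from compound 2 to compound 3 (within the scatter), downward, with wide uncertainty, because compound 1 gives 2.1% with a different group at the same place and compound 2 gives 20%. Compound 3 is estimated at 10%, with a range from 1% to 45%.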

Compound 3, a percentage reported as activity, at one concentration (the size of the read-out at that concentration, not a potency): 0.25%
For compound 3 the middle estimate is 9.8 percentage points above the measured one; the measured number lies below the stated range.
By their numbers in this assay, from the lowest: compounds 3 and 1 (each within the scatter of the next); then compound 2.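

In this assay, the step of a number 19.8 percentage points lower from compound 2 to compound 3 (beyond the scatter) shows that this position on the shared core can carry 4-sulfamoylphenyl, a group with a hydrogen-bond donor and hydrogen-bond acceptors, with no loss of effect relative to 3,4-dimethylphenyl. The step of a number 1.9 percentage points lower from compound 1 to compound 3 (within the scatter) adds that the read-out does not separate sulfamoyl from fluoro on this phenyl ring, so among the three compounds only the 3,4-dimethylphenyl group of compound 2 stands apart, and the two compounds with a single group on the phenyl ring stay level. The data on hand offer no explanation for why the 3,4-dimethylphenyl group differs from the other two.

Still open, on these data alone, is whether a carboxylic acid or an aminomethyl group in place of the sulfamoyl group would keep the number as low, and whether a 4-methylphenyl group would behave like 3,4-dimethylphenyl or like the two compounds that stay level. Since each number comes from a single concentration, compound 1 and compound 3 could still show a stronger or weaker effect relative to each other at other concentrations, which a full concentration series would be needed to show.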